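Chain-end aryl variation: compound 3 to compound 4

The compounds below may be only part of what the source reports. "The series", "measured", "known", "first", "only" and "open" are said of these compounds alone.

Measured so far in a functional assay on 1321-N1 cells for agonist activity at P2Y purinoceptor 4 (Homo sapiens), read by scintillation counting and inositol phosphate accumulation; a lower number here means that less compound is needed, a higher number that more compound is needed for the effect:
Compound 1, `O=C(O)CCCO/N=c1/ccn([C@@H]2O[C@H](COP(=O)(O)OP(=O)(O)OP(=O)(O)O)[C@@H](O)[C@H]2O)c(=O)[nH]1`, gives 470 nM.
Compound 2, `O=c1[nH]/c(=N\OCCCCc2ccccc2)ccn1[C@@H]1O[C@H](COP(=O)(O)OP(=O)(O)OP(=O)(O)O)[C@@H](O)[C@H]1O`, gives 54 nM.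
Compound 3, `O=c1[nH]/c(=N\OCCCc2ccc(F)cc2)ccn1[C@@H]1O[C@H](COP(=O)(O)OP(=O)(O)OP(=O)(O)O)[C@@H](O)[C@H]1O`, gives 105 nM.

Compound 3 stands second highest of the three numbers, nearest to compound 2 and furthest from compound 1. The two steps away from the carboxy compound are an 8.7-fold lower number from compound 1 to compound 2 (0.94 log units; beyond the scatter) and a 4.5-fold lower number from compound 1 to compound 3 (0.65 log units; beyond the scatter), both beyond the scatter. Between the two aryl-ended compounds the step is a 1.9-fold higher number from compound 2 to compound 3 (0.29 log units; within the scatter), which lies within the scatter.

Compound 4, `O=c1[nH]/c(=N\OCCCc2cccc(I)c2)ccn1[C@@H]1O[C@H](COP(=O)(O)OP(=O)(O)OP(=O)(O)O)[C@@H](O)[C@H]1O`, differs from compound 3 in one place: 3-iodophenyl in place of 4-fluorophenyl on a saturated chain carbon, three bonds along the chain from an oxygen. Among the measured compounds shown here, the only measured step that bears on this change is the exchange of one aryl end for another, a 1.9-fold higher number from compound 2 to compound 3 (0.29 log units; within the scatter), and that stayed within the scatter. As far as these compounds go, nothing measured here involves 3-iodophenyl or any other ring-substituted aryl end apart from the fluorinated one, so the effect of the iodine itself is unknown. On this basis no step beyond the scatter is expected in this assay in either direction; the expected step is a 1.1-fold lower number from compound 3 to compound 4 (0.02 log units; within the scatter). Compound 4 is estimated at 100 nM, with a range from 35 nM to 300 nM.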

Compound 4, half-maximal effective concentration: 114 nM
Beside the measured number, compound 4's estimate is 1.1-fold (0.06 log units) below it, and the stated range covers the measured number.
By their numbers in this assay, from the lowest: compounds 2, 3 and 4 (each within the scatter of the next, the first and the last beyond it); then compound 1.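

In this assay, replacing 4-fluorophenyl with 3-iodophenyl on a saturated chain carbon, three bonds along the chain from an oxygen, gives a 1.1-fold higher number from compound 3 to compound 4 (0.04 log units; within the scatter), so this exchange of one halogen-bearing ring for another, with the heavy-atom count unchanged, leaves the number within the scatter. The comparison with the benzyl end gives a 2.1-fold higher number from compound 2 to compound 4 (0.32 log units; beyond the scatter); this step is modest, but unlike the step from compound 2 to compound 3 it lies beyond the scatter. The comparison with the carboxy end gives a 4.1-fold lower number from compound 1 to compound 4 (0.62 log units; beyond the scatter), which adds a third example to the two earlier ones: compound 2, compound 3 and compound 4 all have lower numbers than compound 1.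

As far as these compounds go, the halogen and its ring place differ together between compound 3 and compound 4, so their separate contributions cannot be told apart, and the outcome with an amine or a methoxy group on the ring remains open. No supporting measurement bears on the reason for these steps.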